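The compounds below may be only part of what the source reports. "The series", "measured", "known", "first", "only" and "open" are said of these compounds alone.

Working notes on the coumarin-bearing pyrazoline amides.

Three compounds carry measurements. Compound 1 `O=C(c1ccccc1)N1N=C(c2cc3ccccc3oc2=O)CC1c1ccccc1` gives 5870 nM in a functional assay on PC-3 cells (Homo sapiens) for cytotoxicity, read by MTT assay, with a stated time of 48 h; a lower number here means a stronger inhibitor, a higher number a weaker inhibitor. Compound 2 `O=C(CCl)N1N=C(c2cc3ccccc3oc2=O)CC1c1ccccc1` gives 2980 nM in this assay. Compound 3 `O=C(c1ccccc1Cl)N1N=C(c2cc3ccccc3oc2=O)CC1c1ccccc1` gives 6370 nM in this assay, the highest of the three numbers; against compound 1 it sits within the scatter, and only against compound 2 does the gap, a 2.1-fold higher number from compound 2 to compound 3 (0.33 log units; beyond the scatter), pass beyond it.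

Compound 4 `CCCNCC(=O)N1N=C(c2cc3ccccc3oc2=O)CC1c1ccccc1` is not yet measured. Relative to compound 3 the change is (propylamino)methyl in place of 2-chlorophenyl on a carbonyl carbon. Within the data shown here, two measured steps bear on this exchange at the carbonyl carbon. The move from an aryl to a short substituted chain is seen in a 2.0-fold lower number from compound 1 to compound 2 (0.29 log units; within the scatter), a change that stays within the scatter. The reverse direction, chain to aryl, is a 2.1-fold higher number from compound 2 to compound 3 (0.33 log units; beyond the scatter), modest but beyond the scatter. Both point the same way: replacing the aryl on the carbonyl with a small chain is accompanied by a somewhat lower number in this assay, never by a large one. Among the measured compounds shown here, no measured compound carries an amino chain, so the (propylamino)methyl group itself is unrepresented.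

On that basis compound 4 is expected to land near compound 2, a modest step down from compound 3, a 2.0-fold lower number from compound 3 to compound 4 (0.30 log units; within the scatter). The estimate for compound 4 is 3200 nM, with a range from 1400 nM to 7500 nM.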

Compound 4, half-maximal inhibitory concentration: 7270 nM
The estimate for compound 4 lay 2.3-fold (0.36 log units) below the measured number; low and high end bracket the measured number.
By their numbers in this assay, from the lowest: compounds 2, 1, 3 and 4 (each within the scatter of the next, the first and the last beyond it).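

At the carbonyl carbon, a short chain does not by itself go with a lower number in this assay: (propylamino)methyl in place of 2-chlorophenyl gives a 1.1-fold higher number from compound 3 to compound 4 (0.06 log units; within the scatter) and, in place of phenyl, gives a 1.2-fold higher number from compound 1 to compound 4 (0.09 log units; within the scatter), so neither exchange can be told from the scatter. The chain's end group now counts, as propylamino in place of chloro on the saturated chain carbon gives a 2.4-fold higher number from compound 2 to compound 4 (0.39 log units; beyond the scatter) as a modest step beyond the scatter, and among the compounds shown, chloromethyl alone stands apart from (propylamino)methyl, while its steps to the phenyl and 2-chlorophenyl groups lie on either side of the scatter's edge. Nothing available on these compounds accounts for the difference between the two chains.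

Still open, on these data alone, is whether the step from compound 2 belongs to amines in general or to this one, which a dimethylamino or a piperidine group on the same chain carbon would test. Also open, as far as these compounds go, is how a bromomethyl group or a longer chloroalkyl chain on the carbonyl carbon would compare with chloromethyl in this assay on the shared core.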